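This account rests on a few compounds, and the source may have more. Where it says the series, first, only, none or still open, it means among the compounds named here.

Compound 1 `O=c1cc(/C=N\Nc2ccc([N+](=O)[O-])cc2)c2ccc(OCc3ccccc3)cc2o1` gives > 2000000 nM in a functional assay, read by spectrophotometry, with a stated time of 1 h; a lower number here means a stronger inhibitor, a higher number a weaker inhibitor.
Compound 2 `O=c1cc(/C=N\O)c2ccc(OCc3ccccc3)cc2o1` gives > 2000000 nM in this assay.

For compound 1 the result in this assay is a limit of the assay, not a number. For compound 2 the result in this assay is likewise a limit, so compound 2 stands only at a limit, with no number of its own; this is summed up by the limit of > 2000000 nM in this assay, at which 2 of the 2 values shown sit. The step that the two limits leave unreadable from compound 1 to compound 2 therefore cannot be read. Compound 3 `N/N=C\c1cc(=O)oc2cc(OCc3ccccc3)ccc12` differs from compound 2 by one change: amino in place of hydroxy on a double-bonded nitrogen. For the measured compounds named here, the only measured step, a step that the two limits leave unreadable from compound 1 to compound 2, offers no size to build on, so the expected step of a number no higher from compound 2 to compound 3 (the limit leaves the size open) is none beyond the scatter, and the most likely outcome is that compound 3 also reaches only a limit. The estimate for compound 3 in this assay is 2000000 nM, with a range from 300000 nM to 10000000 nM.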

Compound 3, half-maximal inhibitory concentration: "not active" (no number reported)
Compound 3: no number reported; no gap can be computed for the estimate.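

For the compounds shown here, compound 3 is reported in this assay only as "not active", with no number, so no step from compound 2 to compound 3 can be read. The compounds shown leave open which group on the double-bonded nitrogen, if any, would give a readable number in this assay: the limit of > 2000000 nM in this assay, at which 2 of the 3 values shown sit.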